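The source may hold more compounds than are shown below. What is called first, only, known or untested is meant among the compounds shown, and "the series" means these compounds.

Of the compounds shown here, three of one series have been measured in an assay on membranes from Cerebral cortex for displacement of a labelled ligand from Neuronal acetylcholine receptor; alpha4/beta2 (Rattus norvegicus), with a stated time of 5 min; a lower number here means a stronger inhibitor, a higher number a weaker inhibitor. Compound 1 `CN1CCC[C@H]1[C@H]1COc2cc(N)ccc2O1` gives 74000 nM, compound 2 `CN1CCC[C@H]1[C@H]1COc2c(N)cccc2O1` gives 131 nM and compound 3 `CN1CCC[C@H]1[C@@H]1COc2c(N)cccc2O1` gives 7100 nM. Compound 2 thus stands with the lowest of the three numbers: compound 3 lies nearest, and compound 1 furthest, both beyond the scatter. Among the measured compounds shown here, the only single-change step among the measured compounds is a 54-fold higher number from compound 2 to compound 3 (1.73 log units; beyond the scatter), which rests on (the fact that compounds 2 and 3 differ only in the configuration as drawn).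

Compound 4 `CN1CCC[C@H]1[C@H]1COc2c(O)cccc2O1` has not yet been measured. It differs from compound 2 by hydroxy in place of amino on an aromatic carbon. For the measured compounds named here, no measured step swaps one substituent for another on the aromatic ring; the step from compound 2 to compound 3 concerns configuration alone and so does not bear directly on this exchange. The account therefore works from the value of compound 2 and expects at most a moderate shift in this assay, most likely towards a higher number. Compound 4 is estimated at 300 nM, within 60 nM to 1500 nM, which means an expected step of a 2.3-fold higher number from compound 2 to compound 4 (0.36 log units; beyond the scatter).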

Compound 4, inhibition constant: 1700 nM
Estimate against measurement, compound 4: 5.7-fold (0.75 log units) below; the measured number lies above the stated range.
By their numbers in this assay, from the lowest: compound 2; then compound 4; then compound 3; then compound 1.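

In this assay this aromatic carbon proves sensitive to the identity of its substituent: hydroxy in place of amino gives a 13-fold higher number from compound 2 to compound 4 (1.11 log units; beyond the scatter), a large step for the exchange of one heavy atom. Amino and hydroxy have the same computed counts of hydrogen-bond donors and acceptors and neither carries a net charge, so these counts do not separate compound 2 from compound 4, although the assay does. What is known about these compounds offers no explanation for this step.

From the compounds shown here alone, whether a methoxy or a methylamino group on this carbon would give a number closer to that of compound 2 or to that of compound 4 remains open. Also open, going by these compounds, is whether hydroxy in place of amino would give a step of similar size in the configuration of compound 3.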